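This account rests on a few compounds, and the source may have more. Where it says the series, first, only, none or still open, it means among the compounds named here.

Among the compounds with values here, in an ADME assay on brain (Rattus norvegicus) for protein binding (a higher number here means a larger unbound share of the compound, a lower number a smaller unbound share), compound 2 `Cc1cc(C)c2cc(C(=O)NC3CN(c4ccnc(F)c4F)C3)ccc2n1` gives 0.023, the higher of the two numbers so far, and compound 1 `Cc1cc(C)c2cc(C(=O)NC3CN(c4cc(Cl)ncc4Cl)C3)ccc2n1` gives 0.006. Within the data shown here, the only measured step, a 3.8-fold higher number from compound 1 to compound 2 (0.58 log units; beyond the scatter), put 2,3-difluoropyridin-4-yl in place of 2,5-dichloropyridin-4-yl on an amine nitrogen in a ring. Compound 3 `COc1cc(N2CC(NC(=O)c3ccc4nc(C)cc(C)c4c3)C2)c(Cl)cn1` differs from compound 2 at that same nitrogen: 5-chloro-2-methoxypyridin-4-yl in place of 2,3-difluoropyridin-4-yl on an amine nitrogen in a ring. Its 5-chloro-2-methoxypyridin-4-yl keeps a chloro group, as does the group of compound 1 at 0.006, so a partial return towards that number is expected. The expected change is a 2.6-fold lower number from compound 2 to compound 3 (0.41 log units; beyond the scatter), a modest fall. For compound 3 the estimate is 0.009, with an expected range of 0.004 to 0.02.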

Compound 3, unbound fraction: 0.008
Beside the measured number, compound 3's estimate is 1.1-fold (0.05 log units) above it; the measured number falls inside the stated range.
By their numbers in this assay, from the lowest: compounds 1 and 3 (each within the scatter of the next); then compound 2.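

In this assay the 5-chloro-2-methoxypyridin-4-yl group on the amine nitrogen in a ring gives a 2.9-fold lower number from compound 2 to compound 3 (0.46 log units; beyond the scatter) and so the higher number of compound 2 does not carry over to this group. Methoxy in place of chloro on an aromatic carbon gives a 1.3-fold higher number from compound 1 to compound 3 (0.12 log units; within the scatter) and so this swap does not separate compound 1 from compound 3. Open, as far as these compounds go, is how a single fluoro group, a nitrile or an amine on this six-membered aromatic ring would compare with these groups. No measurement at hand explains either step.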